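Cytotoxicity of two compounds and an expected third

A few compounds are considered here, and "the series" means these few. Any claim that something is new, unique, unknown or untested is made for them only; others in the source may bear on it.

Measured so far:
compound 1, `O=C1c2ccccc2C(=O)N1CCOC(=S)N(C(=O)c1ccc(Br)cc1)c1ccc(Br)cc1`, 73000 nM
compound 2, `O=C1c2ccccc2C(=O)N1CCOC(=S)N(C(=O)c1c(F)cccc1F)c1ccc(Cl)cc1`, 39000 nM

Both compounds were tested in an ADME assay on MT4 cells (Homo sapiens) for cytotoxicity, read by MTT assay; on this read-out lower numbers stand for higher toxicity in this test and higher numbers for lower toxicity in this test. Compound 1 gives 73000 nM, and compound 2 gives 39000 nM. Compound 2 carries the lowest of the two numbers, but the gap to compound 1 lies within the usual scatter of repeated measurements, so the two values show no real difference between them.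

Compound 3, `Cc1cc(C(=O)N(C(=S)OCCN2C(=O)c3ccccc3C2=O)c2ccc(Cl)cc2)c(C)o1`, has not yet been measured in this assay. It differs from compound 2 in one place: 2,5-dimethylfuran-3-yl in place of 2,6-difluorophenyl on a carbonyl carbon. Among the compounds with values here, no step between measured compounds is available to judge what such a change does here, so the expectation rests only on the two measured values, which sit close together. The step from compound 2 to compound 3 is estimated as a 1.2-fold higher number from compound 2 to compound 3 (0.06 log units; within the scatter), that is, no change beyond the scatter. Compound 3 is therefore expected to give about 45000 nM, with a range from 15000 nM to 130000 nM.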

Compound 3, half-maximal cytotoxic concentration: 40000 nM
Compound 3: middle estimate off by 1.1-fold (0.05 log units), on the high side; the range from low to high includes it.
By their numbers in this assay, from the lowest: compounds 2, 3 and 1 (each within the scatter of the next).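

In this assay, within the data shown here, the exchange of 2,6-difluorophenyl for 2,5-dimethylfuran-3-yl on a carbonyl carbon gives a 1.0-fold higher number from compound 2 to compound 3 (0.01 log units; within the scatter), the first step here that isolates a single place. At this position, a six-membered aromatic ring of carbon only can thus give way to a five-membered aromatic ring with one hetero atom and one hydrogen-bond acceptor, with no change beyond the scatter. No measurement at hand bears on why the read-out stays within the scatter across this exchange.

As far as these compounds go, both groups compared here are uncharged aromatic rings, so it remains open whether the read-out would also hold with an amine, a carboxylic acid or a longer alkyl chain on that carbonyl carbon. The compounds shown also give no single-place step for any other part of the structure.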